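The compounds below may be only part of what the source reports. "The series", "measured", "known", "first", "only" and "open" are said of these compounds alone.

Compound 1 `Clc1ccc(C(CCn2ccnc2)Oc2ccccc2)cc1` was tested in an ADME assay on U-937 cells (Homo sapiens) for cytotoxicity, read by MTT assay, with a stated time of 24 h (on this read-out higher numbers stand for lower toxicity in this test and lower numbers for higher toxicity in this test), where compound 1 gives 248000 nM. Among the measured compounds shown here, its only measured neighbour is compound 2 `CC(C)c1ccc(OC(CCn2ccnc2)c2ccc(Cl)cc2)cc1`, which in this assay gives 208000 nM; the step of a 1.2-fold lower number from compound 1 to compound 2 (0.08 log units; within the scatter) is too small to tell the two apart, so compound 1 and compound 2 sit within the scatter of each other. Compound 3 `Clc1ccc(C(CCn2ccnc2)Oc2cc(Cl)cc(Cl)c2)cc1` differs from compound 1 by 3,5-dichlorophenyl in place of phenyl on an oxygen on a saturated carbon. For the measured compounds named here, the one measured step, from compound 1 to compound 2, also swaps hydrogen for a substituent on an aromatic carbon and stayed within the scatter, so it gives little reason to expect a large shift here. The expectation for compound 3 in this assay is therefore a step of a 1.4-fold lower number from compound 1 to compound 3 (0.14 log units; within the scatter) that lies within or only slightly beyond the scatter. Compound 3 is estimated at 180000 nM, with a likely range from 70000 nM to 400000 nM.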

Compound 3, half-maximal cytotoxic concentration: 180000 nM
Estimate against measurement, compound 3: no gap at the digits printed, and the stated range covers the measured number.
By their numbers in this assay, from the lowest: compounds 3, 2 and 1 (each within the scatter of the next).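

In this assay, the swap of phenyl for 3,5-dichlorophenyl on an oxygen on a saturated carbon gives a 1.4-fold lower number from compound 1 to compound 3 (0.14 log units; within the scatter) and so cannot be told apart from no change at all. The earlier step to compound 2 showed this for a single isopropyl group; compound 3 shows that the same holds for a ring carrying two chlorine atoms, a different kind of substituent. Nothing measured alongside these numbers offers an explanation for this result.

The compounds shown leave open whether any group on this ring can move the number beyond the scatter, for instance an amine or a carboxylic acid. They also leave open what happens when the rest of the core of compound 1 is changed, such as by a longer chain.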